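The compounds below may be only part of what the source reports. "The series", "measured", "known", "first", "only" and "open" are said of these compounds alone.

Values in a physicochemical assay for lipophilicity, read by HPLC, at pH 7.4 (a higher number here means a more lipophilic compound, a lower number a more polar compound), for the measured compounds

- compound 1 `Cc1ccccc1C(=O)Nc1cc(Cl)ccn1` gives 3.4
- compound 2 `Cc1ccccc1C(=O)Nc1cc(C#N)ccn1` gives 2.8
- compound 3 `Cc1ccnc(NC(=O)c2ccccc2C)c1` gives 2.8

Compound 3 stands level with compound 2, and the two share the lowest number of the three. Compound 4 `Cc1ccccc1C(=O)Nc1cc(C#Cc2ccccc2)ccn1` has 2-phenylethynyl in place of methyl on an aromatic carbon, opposite the ring nitrogen (2-phenylethynyl in place of methyl on an aromatic carbon). Within the data shown here, three measured steps bear on this change, all swaps among small groups: cyano for chloro (a number 0.60 log units lower from compound 1 to compound 2 (beyond the scatter)), methyl for chloro (a number 0.60 log units lower from compound 1 to compound 3 (beyond the scatter)) and methyl for cyano (no change at the digits printed from compound 2 to compound 3 (within the scatter)). None of them brings in a group of this size, so they offer only a rough scale. A much larger group enters here, so a clearly larger upward step is expected (a number 1.50 log units higher from compound 3 to compound 4 (beyond the scatter)). The estimate for compound 4 is 4.3 (3.7 to 4.9).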

Compound 4, distribution coefficient: 4.7
Compound 4: the middle estimate sits 0.40 log units below what was measured; the measured number falls inside the stated range.
By their numbers in this assay, from the lowest: compounds 2 and 3 (each within the scatter of the next); then compound 1; then compound 4.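

In this assay, this position opposite the ring nitrogen can carry a far larger group than the earlier small swaps, and the number moves much further than those swaps moved it (a number 1.90 log units higher from compound 3 to compound 4 (beyond the scatter)). The rise stays large against the other two small groups as well (a number 1.90 log units higher from compound 2 to compound 4 (beyond the scatter)) and (a number 1.30 log units higher from compound 1 to compound 4 (beyond the scatter)). Nothing measured here explains the size of this rise.

On these data alone, the triple bond and the six-membered aromatic ring enter together, so their shares remain open. A lone ethynyl or a phenyl group directly at this position could separate them, and an amine there would test a very different kind of group.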